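The source may report more compounds than this note shows. Statements on the series, on what has been measured and on what is new or still open speak of the compounds shown alone.

Compound 1 `O=C1CSC(c2ccc(Cl)cc2)N1CCN1CCCCC1` in an ADME assay on Vero cells (Chlorocebus sabaeus) for cytotoxicity, read by neutral red uptake, tested at 98 ug/mL (a lower number here means a stronger effect, a higher number a weaker effect of the compound at the concentration tested), gives 74%.
Compound 2 `COc1ccc(C2SCC(=O)N2CCN2CCCCC2)cc1` in this assay gives 89%.
Compound 3 `O=C1CSC(c2cccc(O)c2)N1CCN1CCCCC1` in this assay gives 100%.

In this assay compound 3 stands highest of the three numbers; compound 2 is nearest and compound 1 furthest below it, both gaps beyond the scatter. Compound 4 `Cc1ccc(C2SCC(=O)N2CCN2CCCCC2)cc1` differs from compound 3 by 4-methylphenyl in place of 3-hydroxyphenyl on a saturated ring carbon. Both measured steps bear on this change: a number 15 percentage points higher from compound 1 to compound 2 (beyond the scatter) and a number 26 percentage points higher from compound 1 to compound 3 (beyond the scatter). Each exchanged the aromatic group on a saturated ring carbon, and each moved the number by a modest amount, upward from compound 1. Going the other way, from the hydroxyphenyl back toward an unsubstituted-type ring, a modest fall is expected, a number 20 percentage points lower from compound 3 to compound 4 (beyond the scatter). Compound 4 is therefore estimated at 80%, within 65% to 95%.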

Compound 4, a percentage reported as activity, at one concentration (the size of the read-out at that concentration, not a potency): 100%
Compound 4: middle estimate off by 20 percentage points, on the low side, and the stated range ends below it.
By their numbers in this assay, from the lowest: compound 1; then compound 2; then compounds 3 and 4 (each within the scatter of the next).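

In this assay, exchanging 3-hydroxyphenyl for 4-methylphenyl on the saturated ring carbon removes the hydrogen-bond donor and acceptor, yet gives no change at the digits printed from compound 3 to compound 4 (within the scatter). On the aromatic carbon, methyl also separates from the other two substituents, with a number 11 percentage points higher from compound 2 to compound 4 (beyond the scatter) and a number 26 percentage points higher from compound 1 to compound 4 (beyond the scatter). No supporting measurement accounts for these results.

From the compounds shown here alone, whether an amine or a carboxylic acid on the aromatic ring would keep the number this high remains open. Going by these compounds, a longer chain in place of methyl is equally open.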